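The compounds below may be only part of what the source reports. "The series", "measured", "known", "first", "only" and "open" are said of these compounds alone.

Compound 1 `CCCCCCc1cn(-c2ccc(O)c(C(=O)NCCC)c2)nn1`: 19700 nM
Compound 2 `CCCNC(=O)c1cc(-n2cc(-c3cccc(Cl)c3)nn2)ccc1O`: > 20000 nM

Among the compounds with values here, in a functional assay on RAW264.7 cells (Mus musculus) for inhibition, read by Griess assay, with a stated time of 20 h (on this read-out higher numbers stand for weaker inhibition and lower numbers for stronger inhibition), compound 1 gives 19700 nM, the only actual number so far. For compound 2 the reading > 20000 nM is a limit.

Compound 3 `CCCNC(=O)c1cc(-n2cc(-c3cc(F)cc(F)c3)nn2)ccc1O` is the next to be read. Its change from compound 1 is 3,5-difluorophenyl in place of hexyl on an aromatic carbon. Within the data shown here, the only measured step bearing on this is an at least 1.0-fold higher number from compound 1 to compound 2 (0.00 log units; that floor lies within the scatter), likewise a replacement of hexyl on that carbon. As far as these compounds go, its true size remains open, as only a floor is known. In this assay no step beyond the scatter is expected in either direction, and a second reading at the limit would not be surprising. The expected change is a 1.0-fold higher number from compound 1 to compound 3 (0.01 log units; within the scatter). Compound 3 is estimated at 20000 nM, with an expected range of 9000 nM to 45000 nM.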

Compound 3, half-maximal inhibitory concentration: > 20000 nM
Compound 3 gave a limit, no number (the forecaster's own chance of this, stated with the estimate: 60%); the middle value sits exactly at the limit.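

Putting 3,5-difluorophenyl in place of hexyl on this aromatic carbon gives, in this assay, an at least 1.0-fold higher number from compound 1 to compound 3 (0.00 log units; that floor lies within the scatter). For compound 3 the reading > 20000 nM is a limit, not a number, so this second phenyl-type replacement of hexyl also yields only a floor. With both 3-chlorophenyl and 3,5-difluorophenyl at this position, the step between compound 2 and compound 3 cannot be read, and the series now has more limits than numbers: the limit of > 20000 nM in this assay, at which 2 of the 3 values shown sit.

As far as these compounds go, whether any group on this carbon gives a number clearly lower than that of compound 1 stays open, as does the true size of both replacements. What a longer chain such as octyl, or a chain ending in a carboxylic acid or an amine, would read at this position is also unknown.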